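This account rests on a few compounds, and the source may have more. Where it says the series, first, only, none or still open, it means among the compounds named here.

The measured compounds in an ADME assay on microsomes from liver (Homo sapiens) for metabolic stability, read by LC-MS, using NADPH, tested at 5 uM; a higher number here means that the compound lasts longer, a lower number that the compound disappears faster:
compound 1 `NS(=O)(=O)c1cc(-c2nnc(CN3CCN(Cc4ccccc4)CC3)o2)c(Cl)cc1SCc1ccccc1`, 0.08 h;
compound 2 `CCOC(=O)c1cn(Cc2nnc(-c3cc(S(N)(=O)=O)c(SCc4ccccc4)cc3Cl)o2)nn1`, 0.085 h;
compound 3 `COc1ccc(-c2cn(Cc3nnc(-c4cc(S(N)(=O)=O)c(SCc5ccccc5)cc4Cl)o3)nn2)cc1`, 0.215 h.

For the measured compounds named here, compound 2 holds the second highest of the three numbers; compound 1 stands within the scatter of it, and the only step beyond the scatter is a 2.5-fold higher number from compound 2 to compound 3 (0.40 log units; beyond the scatter), brought by 4-methoxyphenyl in place of ethoxycarbonyl on an aromatic carbon. Compound 4 `NCc1nnc(-c2cc(S(N)(=O)=O)c(SCc3ccccc3)cc2Cl)o1` differs from compound 2 by amino in place of 4-(ethoxycarbonyl)-1H-1,2,3-triazol-1-yl on a saturated chain carbon bound to an aromatic carbon. Going by the values given here, that measured step swapped a substituent on the triazole rather than removing the whole group, so it bears only loosely on this change, and no measured step removes the group entirely. Compound 4 is therefore expected to show no step beyond the scatter in this assay, with a 1.2-fold higher number from compound 2 to compound 4 (0.07 log units; within the scatter) as the expected step. The estimate for compound 4 in this assay is 0.1 h, within 0.04 h to 0.3 h.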

Compound 4, half-life: 0.263 h
For compound 4 the middle estimate is 2.6-fold (0.42 log units) below the measured one; the measured number falls inside the stated range.
By their numbers in this assay, from the lowest: compounds 1 and 2 (each within the scatter of the next); then compounds 3 and 4 (each within the scatter of the next).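

In this assay, the whole 4-(ethoxycarbonyl)-1H-1,2,3-triazol-1-yl group on this saturated chain carbon can give way to amino, with a 3.1-fold higher number from compound 2 to compound 4 (0.49 log units; beyond the scatter). The earlier step, a 2.5-fold higher number from compound 2 to compound 3 (0.40 log units; beyond the scatter), changed only a substituent on the triazole, whereas this one shows that the number can also rise when the triazole is absent and amino stands in its place. No measured evidence here accounts for this step. The compounds shown leave open whether the higher number belongs to amino itself or follows from the departure of the triazole; a hydroxyl or a dimethylamino group on the same carbon would bear on that.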